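Methyl to chloro swap on two cores

A few compounds are considered here, and "the series" means these few. Any claim that something is new, unique, unknown or untested is made for them only; others in the source may bear on it.

Values in a functional assay on MDA-MB-231 cells (Homo sapiens) for antiproliferative activity, read by XTT assay, with a stated time of 48 h (on this read-out higher numbers stand for weaker inhibition and lower numbers for stronger inhibition), for the measured compounds:
Compound 1 `CC(=O)OC[C@H]1O[C@@H](n2cc(CN(c3ccc(C)cc3)S(=O)(=O)c3ccccc3)nn2)[C@H](OC(C)=O)[C@@H]1OC(C)=O`: 205000 nM
Compound 2 `CC(=O)OC[C@H]1O[C@@H](n2cc(CN(c3ccc(Cl)cc3)S(=O)(=O)c3ccccc3)nn2)[C@H](OC(C)=O)[C@@H]1OC(C)=O`: 250000 nM
Compound 3 `CC(=O)OC[C@H]1O[C@@H](n2cc(CN(c3ccc(C)cc3)S(=O)(=O)c3ccccc3)nn2)[C@H](OC(C)=O)[C@@H](OC(C)=O)[C@@H]1OC(C)=O`: 180000 nM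

Compound 1 and compound 2 differ by chloro in place of methyl on an aromatic carbon; that change gave a 1.2-fold higher number from compound 1 to compound 2 (0.09 log units; within the scatter). Compound 3 carries a different core from compound 1, and the difference between the two cores is not broken down here; in this assay the numbers for compound 1, compound 2 and compound 3 all lie within the scatter of one another, so no order among them is read. The unmeasured compound 4 `CC(=O)OC[C@H]1O[C@@H](n2cc(CN(c3ccc(Cl)cc3)S(=O)(=O)c3ccccc3)nn2)[C@H](OC(C)=O)[C@@H](OC(C)=O)[C@@H]1OC(C)=O` is compound 3 with chloro in place of methyl on an aromatic carbon. The place of this swap reads word for word as the place of the swap in the measured pair, so it counts as the same change. Compound 4 is expected to show a step of a 1.2-fold higher number from compound 3 to compound 4 (0.08 log units; within the scatter), alongside the measured 1.2-fold higher number from compound 1 to compound 2 (0.09 log units; within the scatter), because the same change gave a 1.2-fold higher number from compound 1 to compound 2 (0.09 log units; within the scatter) on the core of compound 1. For compound 4 in this assay the estimate is 215000 nM, expected to fall between 110000 nM and 420000 nM.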

Compound 4, half-maximal inhibitory concentration: 135000 nM
Compound 4: the middle estimate sits 1.6-fold (0.20 log units) above what was measured, and the stated range covers the measured number.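

In this assay, chloro in place of methyl on an aromatic carbon gives a 1.3-fold lower number from compound 3 to compound 4 (0.12 log units; within the scatter). Set beside the step on the core of compound 1, this step shows no difference between the two cores that can be read: the same change on two cores in this assay, a 1.2-fold higher number (0.09 log units; within the scatter) from compound 1 to compound 2 and a 1.3-fold lower number (0.12 log units; within the scatter) from compound 3 to compound 4, 1.6-fold (0.21 log units) apart, within the scatter of two such steps. What carries over is only that 4-methylphenyl to 4-chlorophenyl stays within the scatter on both cores; the steps point in opposite directions, but neither step nor the gap between them lies beyond the scatter, so no direction for the change is shown, and two pairs do not show that it would behave the same way on any other core.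

The compounds shown leave open whether an amine, a carboxylic acid or a longer chain in place of the methyl or chloro would move the number beyond the scatter. Also open, from the compounds shown here alone, is what free hydroxyl groups in place of the acetate groups would do on either core.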